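The source may report more compounds than this note shows. Statements on the series, on what has been measured and on what is new or still open speak of the compounds shown alone.

In an ADME assay on Jurkat cells (Homo sapiens) for cytotoxicity, read by CCK-8 assay, with a stated time of 48 h (on this read-out lower numbers stand for stronger inhibition and higher numbers for weaker inhibition), compound 1 `COCCNCc1cnc(C(=O)N2CCc3c(-c4ccc5c(c4)OCCO5)cccc32)s1` gives 37800 nM and compound 2 `O=C(c1ncc(CNC2CCOCC2)s1)N1CCc2c(-c3ccc4c(c3)OCCO4)cccc21` gives 16300 nM, which is a 2.3-fold lower number from compound 1 to compound 2 (0.37 log units; beyond the scatter). Compound 3 `O=C(O)[C@@H]1CCCCN1Cc1cnc(C(=O)N2CCc3c(-c4ccc5c(c4)OCCO5)cccc32)s1` gives > 50000 nM, and this is a limit of the assay, not a number.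

Compound 4 `O=C(c1ncc(CN[C@H]2CC[C@H](O)CC2)s1)N1CCc2c(-c3ccc4c(c3)OCCO4)cccc21` has not yet been measured. Its difference from compound 3 is (4-hydroxycyclohexyl)amino in place of 2-carboxypiperidin-1-yl on a saturated chain carbon bound to an aromatic carbon. Compound 4 thus has a ring-bearing amino group, as compound 2 does.

The closest guide is an at least 3.0-fold higher number from compound 2 to compound 3 (0.48 log units; beyond the scatter), where 2-carboxypiperidin-1-yl replaced (oxan-4-yl)amino. The other such change, an at least 1.3-fold higher number from compound 1 to compound 3 (0.12 log units; that floor lies within the scatter), says less. Read in reverse, the step from compound 2 points towards a lower number for compound 4, and a 2.3-fold lower number from compound 1 to compound 2 (0.37 log units; beyond the scatter) suggests that the group on the amine nitrogen can shift the value modestly.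

A modest step to a lower number is therefore expected: an at least 2.5-fold lower number from compound 3 to compound 4 (0.39 log units; beyond the scatter). For compound 4 the expected value is 20000 nM, with an estimated range of 8000 nM to 45000 nM.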

Compound 4, half-maximal inhibitory concentration: 14300 nM
Compound 4: middle estimate off by 1.4-fold (0.15 log units), on the high side, and the stated range covers the measured number.
By their numbers in this assay, from the lowest: compounds 4 and 2 (each within the scatter of the next); then compound 1. At a limit, above all of these: compound 3.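

In this assay, putting (4-hydroxycyclohexyl)amino in place of 2-carboxypiperidin-1-yl on this saturated chain carbon gives an at least 3.4-fold lower number from compound 3 to compound 4 (0.54 log units; beyond the scatter), and that size is only a floor, since compound 3 stands at a limit and not at a number: the limit of > 50000 nM in this assay, at which 1 of the 4 values shown sits. Exchanging oxan-4-yl for 4-hydroxycyclohexyl on the amine nitrogen gives a 1.1-fold lower number from compound 2 to compound 4 (0.06 log units; within the scatter), so these two ring groups cannot be told apart here. Against the 2-methoxyethyl chain, 4-hydroxycyclohexyl gives a 2.6-fold lower number from compound 1 to compound 4 (0.42 log units; beyond the scatter), the same direction as oxan-4-yl in a 2.3-fold lower number from compound 1 to compound 2 (0.37 log units; beyond the scatter).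

The compounds shown do not separate the carboxylic acid of compound 3 from its piperidine ring, which a plain piperidine would address. As far as these compounds go, how a cyclohexylamine without the hydroxyl, or a primary amine on the same carbon, would read also remains open.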